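Swapping chloro for fluoro on the benzyl group of compound 3

The source may hold more compounds than are shown below. What is called first, only, known or untested is meant among the compounds shown, and "the series" means these compounds.

Three compounds have been measured in an assay on Cerebral cortex for displacement of a labelled ligand from adenosine receptor A1 (Bos taurus); on this read-out higher numbers stand for weaker inhibition and lower numbers for stronger inhibition:

compound 1 `CCNc1nc(-c2ccccc2)nc2c1nnn2Cc1ccccc1F` gives 11 nM
compound 2 `Fc1ccccc1Cn1nnc2c(NC3CC3)nc(-c3ccccc3)nc21` gives 15 nM
compound 3 `OCCCNc1nc(-c2ccccc2)nc2c1nnn2Cc1ccccc1Cl` gives 33 nM

Compound 3 stands highest of the three numbers in this assay. Its nearest neighbour is compound 2, whose number is lower by a margin beyond the scatter, and compound 1 lies further away still, also beyond the scatter. Among the measured compounds shown here, the one step between compounds that differ in a single place, a 1.4-fold higher number from compound 1 to compound 2 (0.13 log units; within the scatter), concerns the group on the amine nitrogen and stays within the scatter.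

Compound 4 `OCCCNc1nc(-c2ccccc2)nc2c1nnn2Cc1ccccc1F` differs from compound 3 by fluoro in place of chloro on an aromatic carbon. For the measured compounds named here, no measured pair shows this same exchange on its own, so the step from compound 1 to compound 2 does not bear on it directly; compounds 1 and 2 merely show that a 2-fluorobenzyl group is compatible with low numbers when the amine substituent is ethyl or cyclopropyl. Going by the values given here, with no single-change precedent, the step expected in this assay for compound 4 is small, a 1.3-fold lower number from compound 3 to compound 4 (0.12 log units; within the scatter), leaning toward a slightly lower number but not confidently beyond the scatter. Compound 4 is therefore estimated at 25 nM, with a range from 10 nM to 70 nM.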

Compound 4, inhibition constant: 3.7 nM
For compound 4 the middle estimate is 6.8-fold (0.83 log units) above the measured one; measured number below the stated range.
By their numbers in this assay, from the lowest: compound 4; then compounds 1 and 2 (each within the scatter of the next); then compound 3.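

In this assay, among the compounds shown here, the exchange of 2-chlorobenzyl for 2-fluorobenzyl gives an 8.9-fold lower number from compound 3 to compound 4 (0.95 log units; beyond the scatter), the first single-change reading at this position, and it shows that the choice of halogen matters when 3-hydroxypropyl sits on the amine nitrogen. With 2-fluorobenzyl held constant, the amine substituent also produces steps beyond the scatter, a 4.1-fold lower number from compound 2 to compound 4 (0.61 log units; beyond the scatter) and a 3.0-fold lower number from compound 1 to compound 4 (0.47 log units; beyond the scatter), whereas the earlier change from ethyl to cyclopropyl gave only a 1.4-fold higher number from compound 1 to compound 2 (0.13 log units; within the scatter). Nothing in the data at hand explains these steps.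

From the compounds shown here alone, whether fluoro in place of chloro gives a step of similar size with ethyl or cyclopropyl on the amine nitrogen remains open, as the 2-chlorobenzyl group appears here only with 3-hydroxypropyl. Also open, going by these compounds, is how bromo or methyl in place of the halogen on the benzyl group, or a 4-hydroxybutyl or aminopropyl chain on the amine nitrogen, would read in this assay.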